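Three Cytotoxicity Limits and One Untested Benzyl Amine

A few compounds are considered here, and "the series" means these few. Any claim that something is new, unique, unknown or untested is made for them only; others in the source may bear on it.

Compound 3 `Cc1ccc2[nH]c(=O)c(CN(Cc3ccc(C(C)(C)C)cc3)[C@H](CO)c3ccccc3)cc2c1` was tested in a toxicity assay on MDCK cells (Canis lupus familiaris) for cytotoxicity, read by crystal violet staining, with a stated time of 48 h; on this read-out higher numbers stand for lower toxicity in this test and lower numbers for higher toxicity in this test. In this assay compound 3 gives > 10000 nM, which is a limit of the assay rather than a number. The two other values shown are also limits, so compound 3 cannot be placed above or below them. Compound 1 `CCCCOc1ccc(CN(Cc2ccc(C(C)(C)C)cc2)Cc2cc3cc(C)ccc3[nH]c2=O)cc1` gives > 5000 nM in this assay, again a limit. Compound 2 `Cc1ccc2[nH]c(=O)c(CN(Cc3ccc(C(N)=O)cc3)Cc3ccc(C(C)(C)C)cc3)cc2c1` gives > 5000 nM in this assay, likewise a limit. The three steps between these compounds are therefore unreadable: a step that the two limits leave unreadable from compound 1 to compound 2, a step that the two limits leave unreadable from compound 1 to compound 3 and a step that the two limits leave unreadable from compound 2 to compound 3. Going by the values given here, the only evidence is the limit of > 10000 nM in this assay, at which 1 of the 3 values shown sits, and (the limit of > 5000 nM in this assay, at which 2 of the 3 values shown sit).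

Compound 4 `Cc1ccc2[nH]c(=O)c(CN(Cc3ccc(C(C)(C)C)cc3)Cc3ccc(N(C)C)c(Cl)c3)cc2c1` differs from compound 3 in a single place: 3-chloro-4-(dimethylamino)benzyl in place of 2-hydroxy-1-phenylethyl on an amine nitrogen. Among the compounds with values here, none of the measured steps involves this group, and none of them is readable, so no size can be read across for this change. The expectation is simply that compound 4 will behave like the three measured compounds, with a step from compound 3 of an at least 1.1-fold lower number from compound 3 to compound 4 (0.04 log units; that floor lies within the scatter), meaning no movement beyond the scatter. On that basis compound 4 is estimated at 9000 nM in this assay, with a range from 3000 nM to 25000 nM, and most likely the assay will again report only a limit.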

Compound 4, half-maximal cytotoxic concentration: > 10000 nM
Compound 4 gave a limit, no number; the forecaster's own chance of this, stated with the estimate: 70%; at least 1.1-fold (0.04 log units) between middle value and limit.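

In this assay compound 4 gives > 10000 nM, which is a limit and not a number, and none of the steps to it from compound 1, compound 2 or compound 3 can be read. All four values are limits, so the compounds shown leave open the concentration at which any of them harms these cells and whether any single change shifts it.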